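This account rests on a few compounds, and the source may have more. Where it says the series, first, only, none or still open, it means among the compounds named here.

Compound 3 `COc1ccc(C(=O)/C=C/c2ccc(OCc3cn(Cc4ccccc4F)nn3)cc2)cc1` gives in a functional assay on MIA PaCa-2 cells (Homo sapiens) for inhibition, read by MTT assay, with a stated time of 48 h, tested at 10 uM (on this read-out higher numbers stand for more inhibition of growth at the one concentration tested and lower numbers for less inhibition of growth), a value of 19%, the lowest of the three numbers recorded; compound 1 `O=C(/C=C/c1ccc(OCc2cn(Cc3ccc(F)cc3)nn2)cc1)c1ccc(Br)cc1` stands nearest with 32%, and compound 2 `COc1ccc(C(=O)/C=C/c2ccc(OCc3cn(Cc4cccc(Br)c4)nn3)cc2)cc1` stands furthest with 50%. Compound 4 `COc1ccc(C(=O)/C=C/c2ccc(OCc3cn(Cc4ccc(F)cc4)nn3)cc2)cc1` differs from compound 3 by 4-fluorophenyl in place of 2-fluorophenyl on a saturated chain carbon bound to an aromatic nitrogen. Going by the values given here, only one measured step touches this part of the molecule: a number 31 percentage points lower from compound 2 to compound 3 (beyond the scatter), a large fall. Among the compounds with values here, compound 1 carries the same 4-fluorobenzyl group as compound 4, though its other end differs from that of compound 3, so no single step between them is counted. Because compound 1 gives 32% with that group, a modest rise is expected, a number 16 percentage points higher from compound 3 to compound 4 (beyond the scatter). Compound 4 is therefore estimated at 35%, with a range from 15% to 55%.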

Compound 4, percent growth inhibition at one concentration: 6%
Compound 4: the middle estimate sits 29 percentage points above what was measured; measured number below the stated range.
By their numbers in this assay, from the lowest: compound 4; then compound 3; then compound 1; then compound 2.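

In this assay, 4-fluorophenyl in place of 2-fluorophenyl gives a number 13 percentage points lower from compound 3 to compound 4 (beyond the scatter), so the place of the fluorine on this ring alone changes the number. Replacing 3-bromophenyl with 4-fluorophenyl gives a number 44 percentage points lower from compound 2 to compound 4 (beyond the scatter), a larger fall than the one already seen with 2-fluorophenyl. The other end of the molecule also counts, since methoxy in place of bromo gives a number 26 percentage points lower from compound 1 to compound 4 (beyond the scatter).

Nothing available explains these falls. From the compounds shown here alone, how an unsubstituted benzyl group or an aminobenzyl group would read at this position remains open.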